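Swapping chloro for hydroxy in a two-compound series

The source may report more compounds than this note shows. Statements on the series, on what has been measured and on what is new or still open speak of the compounds shown alone.

In a functional assay on MCF7 cells (Homo sapiens) for antiproliferative activity, read by MTT assay, with a stated time of 72 h (on this read-out higher numbers stand for weaker inhibition and lower numbers for stronger inhibition), compound 1 (`COc1cc(-n2cnc3ccc(-c4cccc(C)c4)cc32)cc(OC)c1OC`) gives 360 nM and compound 2 (`COc1cc(-n2cnc3ccc(-c4ccc(Cl)cc4)cc32)cc(OC)c1OC`) gives 1320 nM as the higher of the two numbers, so it is the weaker inhibitor of the pair. Compound 3 (`COc1cc(-n2cnc3ccc(-c4ccc(O)cc4)cc32)cc(OC)c1OC`) is still unmeasured. The change from compound 2 to compound 3 is hydroxy in place of chloro on an aromatic carbon and amounts to hydroxy in place of chloro on an aromatic carbon, turning 4-chlorophenyl into 4-hydroxyphenyl. Among the compounds with values here, the only measured step that bears on it is a 3.7-fold higher number from compound 1 to compound 2 (0.56 log units; beyond the scatter) at the same group. That step shows that this group can move the number, but it involves no hydroxy, so it offers a scale and no direction. A smaller step, not beyond the scatter, is therefore expected in this assay and leans slightly toward the lower value of compound 1. The expected step is a 1.5-fold lower number from compound 2 to compound 3 (0.17 log units; within the scatter) in this estimate. For compound 3 the estimated value is 900 nM with an expected range from 280 nM to 2900 nM in repeat measurements.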

Compound 3, half-maximal inhibitory concentration: 4160 nM
Compound 3: the middle estimate sits 4.6-fold (0.66 log units) below what was measured, and the stated range ends below it.
By their numbers in this assay, from the lowest: compound 1; then compound 2; then compound 3.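

In this assay, hydroxy in place of chloro on the aromatic carbon gives a 3.2-fold higher number from compound 2 to compound 3 (0.50 log units; beyond the scatter) and so shows that this position responds to the exchange of a single heavy atom, with the hydrogen-bond donor and acceptor of hydroxy going with the weaker inhibition. Replacing 3-methylphenyl with 4-hydroxyphenyl gives a 12-fold higher number from compound 1 to compound 3 (1.06 log units; beyond the scatter) as the widest gap among the three compounds, and both the 4-chlorophenyl and the 4-hydroxyphenyl compounds give higher numbers than compound 1. No measurement at hand explains this order.

Compound 1 differs from the other two in both the place and the identity of its group, so the effects of these two features cannot be separated. On these data alone, whether an amine or a carboxylic acid at the place of the hydroxy would raise or lower the number remains open.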